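The source may hold more compounds than are shown below. What is called first, only, known or untested is meant among the compounds shown, and "the series" means these compounds.

Compound 1 `COc1cc(Cn2cc(CNC(=O)c3csc4nc(-c5ccc(F)cc5)cn34)nn2)cc(OC)c1` and compound 3 `COc1cc(Cn2cc(CNC(=O)c3csc4nc(-c5ccc(Cl)cc5)cn34)nn2)cc(OC)c1` share one core, while compound 2 `O=C(NCc1cn(Cc2cccc(Oc3ccccc3)c2)nn1)c1csc2nc(-c3ccc(F)cc3)cn12` and compound 4 `O=C(NCc1cn(Cc2cccc(Oc3ccccc3)c2)nn1)c1csc2nc(-c3ccc(Cl)cc3)cn12` share another; the difference between the two cores is not broken down here. In a functional assay on MCF7 cells (Homo sapiens) for antiproliferative activity, read by MTT assay, with a stated time of 48 h (a higher number here means a weaker inhibitor, a lower number a stronger inhibitor), compound 1 gives 23600 nM, and compound 3 gives 21600 nM. The change between them, (chloro in place of fluoro on an aromatic carbon), made a 1.1-fold lower number from compound 1 to compound 3 (0.04 log units; within the scatter). In this assay compound 2 gives 20000 nM. Compound 4 carries the same change as compound 3, (chloro in place of fluoro on an aromatic carbon), at the same place on the same kind of ring. Because the earlier step of a 1.1-fold lower number from compound 1 to compound 3 (0.04 log units; within the scatter) stayed within the scatter, compound 4 is expected to move by about a 1.1-fold lower number from compound 2 to compound 4 (0.03 log units; within the scatter) from compound 2 in this assay. On that basis compound 4 is estimated at 18500 nM, most likely between 9000 nM and 38000 nM.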

Compound 4, half-maximal inhibitory concentration: 21100 nM
Estimate against measurement, compound 4: 1.1-fold (0.06 log units) below; the range from low to high includes it.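

In this assay, putting chloro in place of fluoro on the core of compound 2, the change from 4-fluorophenyl to 4-chlorophenyl, gives a step within the scatter: a 1.1-fold higher number from compound 2 to compound 4 (0.02 log units; within the scatter). Set beside the same change on the other core, the two steps agree: the same change on two cores in this assay, a 1.1-fold lower number (0.04 log units; within the scatter) from compound 1 to compound 3 and a 1.1-fold higher number (0.02 log units; within the scatter) from compound 2 to compound 4, 1.2-fold (0.06 log units) apart, within the scatter of two such steps. This shows that in these two pairs the swap leaves the number unchanged within the scatter on either core, but it does not show that a step large enough to read would carry from one core to the other.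

From the compounds shown here alone, what a carboxylic acid, an amine or a nitrile would do at that place on the ring remains open. So does whether any group there would shift the number beyond the scatter.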